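The source may report more compounds than this note shows. Statements on the series, on what has been measured and on what is new or still open speak of the compounds shown alone.

Measured in an ADME assay on microsomes from liver (Rattus norvegicus) for metabolic stability, read by LC-MS, with a stated time of 30 min, tested at 1 uM; on this read-out lower numbers stand for a less stable compound and higher numbers for a more stable compound:
Compound 1 `CC(C)(C)NCc1cc(Cl)cc(Nc2nc3cc(F)c(F)cc3n2Cc2ccc(C(F)(F)F)cc2)c1O`: 94%
Compound 2 `CC(C)(C)NCc1cc(Cl)cc(Nc2nc3ccccc3n2Cc2ccc(C(F)(F)F)cc2)c1O`: 9%
Compound 3 `CCNCc1cc(C)cc(Nc2nc3cc(F)c(F)cc3n2Cc2ccc(C(F)(F)F)cc2)c1O`: 77%

Compound 2 stands lowest of the three, and both other compounds lie beyond the scatter above it. Compound 4 `Cc1cc(CNC(C)(C)C)c(O)c(Nc2nc3ccccc3n2Cc2ccc(C(F)(F)F)cc2)c1` is not yet measured. It departs from compound 2 by one swap: methyl in place of chloro on an aromatic carbon. Within the data shown here, no measured pair isolates this swap. Compound 1 and compound 3 carry two fluorines on the shared core, which compound 2 and compound 4 lack. With compound 2 at 9% as the closest reference, no step beyond the scatter is expected in this assay. The estimated change is a number 1 percentage points lower from compound 2 to compound 4 (within the scatter). The expected value for compound 4 is 8%, within an estimated range of 1% to 22%.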

Compound 4, percent of the compound remaining: 41%
Compound 4: the middle estimate sits 33 percentage points below what was measured, outside the stated range (above it).
By their numbers in this assay, from the lowest: compound 2; then compound 4; then compound 3; then compound 1.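

In this assay the carbon para to a hydroxy group proves sensitive to what it carries: methyl in place of chloro gives a number 32 percentage points higher from compound 2 to compound 4 (beyond the scatter) on the shared core without the two fluorines. Among these compounds, this is the first pair of compounds that differ in this one place, so the swap can now be read on its own. Nothing available explains why the step occurs.

Going by these compounds, whether the swap has a similar effect on the core carrying two fluorines remains open. So does the outcome with a methoxy group, a nitrile or an amine at this position.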